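Carboxy gives way to chloro at the assay limit

A few compounds are considered here, and "the series" means these few. Any claim that something is new, unique, unknown or untested is made for them only; others in the source may bear on it.

Measured in an ADME assay on HepG2 cells (Homo sapiens) for cytotoxicity, with a stated time of 72 h; a higher number here means that more compound is needed for the effect, a lower number that less compound is needed:
Compound 1 `Cc1cc(NC(=O)Nc2cccc(F)c2)c2ccccc2n1`: > 25000 nM (a limit)
Compound 2 `Cc1cc(NC(=O)Nc2ccc(C(=O)O)cc2)c2ccccc2n1`: > 25000 nM (a limit)

Compound 2 gives > 25000 nM, which is a limit and not a number. The only reference point here is the limit of > 25000 nM in this assay, at which 2 of the 2 values shown sit. In compound 3 `Cc1cc(NC(=O)Nc2ccc(Cl)cc2)c2ccccc2n1`, chloro takes the place of carboxy on an aromatic carbon, para to a large group (chloro in place of carboxy on an aromatic carbon). For the measured compounds named here, no measured step links two compounds, so the size of this change in this assay can only be expected, and no shift beyond the scatter is anticipated. That expectation rests on compound 1, which has no carboxy group and gives > 25000 nM, again a limit. The expected move is a number no higher from compound 2 to compound 3 (the limit leaves the size open). For compound 3 the estimated value is 25000 nM, with an expected range from 10000 nM to 40000 nM.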

Compound 3, half-maximal effective concentration: > 25000 nM
Compound 3: no number, only a limit; the forecaster's own chance of this, stated with the estimate: 75%; the middle value sits exactly at the limit.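

In this assay compound 3 gives > 25000 nM, a limit and not a number, and the steps to it from compound 1 and compound 2 cannot be read. The compounds shown leave open whether chloro and carboxy differ at all in this assay, and what number any of the three would give.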